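The compounds below may be only part of what the source reports. "The series", "measured", "known", "first", "only" and "open" are said of these compounds alone.

Working notes on the series.

Compound 1 `COc1ccc(CN(C(=O)CSC(=S)N2CCN(C(=O)OC(C)(C)C)CC2)c2ccc(Cl)cc2)cc1` and compound 2 `COc1ccc(CN(C(=O)CSC(=S)N2CCN(C(=O)OC(C)(C)C)CC2)c2ccc(Br)cc2)cc1` share one core; compound 3 `COc1cc(N(Cc2ccc(Cl)cc2)C(=O)CSC(=S)N2CCN(C(=O)OC(C)(C)C)CC2)cc(OC)c1OC` and compound 4 `COc1cc(N(Cc2ccc(Br)cc2)C(=O)CSC(=S)N2CCN(C(=O)OC(C)(C)C)CC2)cc(OC)c1OC` share another. The difference between the two cores is not broken down here.

In a functional assay on MGC-803 cells (Homo sapiens) for inhibition, read by CCK-8 assay, with a stated time of 48 h (on this read-out lower numbers stand for stronger inhibition and higher numbers for weaker inhibition), compound 1 reaches only a limit of the assay, > 20000 nM. In this assay compound 2 likewise gives a limit, > 20000 nM. The change from compound 1 to compound 2 is bromo in place of chloro on an aromatic carbon, and the step it made, a step that the two limits leave unreadable from compound 1 to compound 2, cannot be sized, because both values sit at the limit of > 20000 nM in this assay, at which 2 of the 3 values shown sit.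

For the measured compounds named here, compound 3 is the one compound here with a number: in this assay compound 3 gives 12900 nM.

Compound 4 is not yet measured. It differs from compound 3 by bromo in place of chloro on an aromatic carbon, the same change as that from compound 1 to compound 2; the place of the change is described in the same words for both pairs, while the difference cut one bond further out also reads 4-chlorobenzyl to 4-bromobenzyl. Going by the values given here, with the earlier step unreadable, the only footing for compound 4 is the value of compound 3, 12900 nM, and a step from compound 3 to compound 4 of about a 1.1-fold lower number from compound 3 to compound 4 (0.03 log units; within the scatter) is expected, that is, a change within the usual scatter. On that basis compound 4 is estimated in this assay at 12000 nM, with a likely range from 5000 nM to 28000 nM.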

Compound 4, half-maximal inhibitory concentration: 12400 nM
Compound 4: middle estimate off by 1.0-fold (0.01 log units), on the low side; low and high end bracket the measured number.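

In this assay, bromo in place of chloro on the core of compound 3 gives a 1.0-fold lower number from compound 3 to compound 4 (0.02 log units; within the scatter), so on this core the two halogens cannot be told apart. The same change on the core of compound 1 gives no size to set beside this step, because compound 1 and compound 2 both give only a limit of the assay and not a number: the limit of > 20000 nM in this assay, at which 2 of the 4 values shown sit. The series therefore holds a single readable pair, which shows that the exchange is without readable effect on one core but does not show that this result carries over to the other, and no agreement or disagreement between the two cores can be claimed from these compounds.

The compounds shown hold only chloro and bromo at this place, so it remains open whether an amine or a carboxylic acid there would give a value clearly different from that of compound 3, 12900 nM. As far as these compounds go, it also remains open whether the same halogen exchange would stay within the usual scatter on the core of compound 1 if an analogue on that core gave a number rather than a limit.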